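The compounds below may be only part of what the source reports. "The series", "measured", "known", "first", "only" and "open" are said of these compounds alone.

Measured so far in an ADME assay on microsomes from liver (Homo sapiens) for metabolic stability, with a stated time of 60 min, tested at 1 mg/mL; on this read-out higher numbers stand for fast clearance and lower numbers for slow clearance
- compound 1 `COc1nc2ccc(Br)cc2cc1[C@@H](c1cc(C)c(C)s1)[C@@](O)(CCN(C)C)c1cccc(F)c1` gives 12 mL.min-1.g-1
- compound 2 `COc1nc2ccc(Br)cc2cc1[C@@H](c1cccnc1N(C)C)[C@@](O)(CCN(C)C)c1cccc(F)c1` gives 45 mL.min-1.g-1

Of these two numbers, the higher belongs to compound 2. Within the data shown here, the only measured step is a 3.8-fold higher number from compound 1 to compound 2 (0.57 log units; beyond the scatter), a modest change that lies beyond the usual scatter.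

The unmeasured compound 3 `COc1nc2ccc(Br)cc2cc1[C@@H](c1ccc(N(C)C)nc1)[C@@](O)(CCN(C)C)c1cccc(F)c1` keeps the shared core and differs in one group: 6-(dimethylamino)pyridin-3-yl in place of 2-(dimethylamino)pyridin-3-yl on a saturated chain carbon bound to an aromatic carbon and a saturated chain carbon. The group that leaves and the group that enters hold the same atoms, joined differently.

The measured step replaced a 4,5-dimethylthiophen-2-yl with a 2-(dimethylamino)pyridin-3-yl, a different kind of change. Among the measured compounds shown here, it shows only that a swap on this saturated chain carbon can shift the number in this assay by a modest amount. For the measured compounds named here, no measured pair compares the two dimethylamino arrangements, so the data support no direction. The expectation therefore starts from compound 2 at 45 mL.min-1.g-1.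

The expected change is a 1.1-fold lower number from compound 2 to compound 3 (0.05 log units; within the scatter), which would stay within the scatter. The estimate for compound 3 is 40 mL.min-1.g-1, with an expected range from 16 mL.min-1.g-1 to 100 mL.min-1.g-1.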

Compound 3, intrinsic clearance in microsomes: 38 mL.min-1.g-1
For compound 3 the middle estimate is 1.1-fold (0.02 log units) above the measured one, and the stated range covers the measured number.
By their numbers in this assay, from the lowest: compound 1; then compounds 3 and 2 (each within the scatter of the next).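

Exchanging 2-(dimethylamino)pyridin-3-yl for 6-(dimethylamino)pyridin-3-yl, two groups with the same atoms joined differently, gives a 1.2-fold lower number from compound 2 to compound 3 (0.07 log units; within the scatter) in this assay, so at this saturated chain carbon, this rearrangement cannot be told apart from the ordinary spread of repeated measurements. The comparison with the thiophene compound gives a 3.2-fold higher number from compound 1 to compound 3 (0.50 log units; beyond the scatter), which means that the earlier modest gap from 4,5-dimethylthiophen-2-yl is not tied to only one of the two dimethylaminopyridine arrangements, since compound 2 and compound 3 both stand clearly above compound 1. Nothing measured alongside these clearance numbers explains either the gap or the lack of one.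

The compounds shown leave open whether the gap to compound 1 goes with the pyridine part or with the dimethylamino group, as each step from compound 1 replaces both at once. A plain pyridin-3-yl carrying no amine, or a thiophene carrying a dimethylamino group, would pull those two parts apart at this same carbon.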